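Swapping Bromine for a Third Fluorine on the Benzyl Group

The source may report more compounds than this note shows. Statements on the series, on what has been measured and on what is new or still open speak of the compounds shown alone.

Three close relatives of one core have been measured in an assay on FRT cells for positive allosteric modulation of Cystic fibrosis transmembrane conductance regulator variant N1303K (Homo sapiens), in the presence of a further agent that is not named here; on this read-out higher numbers stand for an effect only at larger amounts of compound and lower numbers for an effect already at smaller amounts. Compound 1 `COc1ccc2[nH]c3c(c2c1)CCNC31CCN(Cc2ccc(Br)c(F)c2)CC1` gives 1800 nM, which places it second highest of the three numbers. Compound 2 `COc1ccc2[nH]c3c(c2c1)CCNC31CCN(Cc2ccc(Br)cc2F)CC1` gives 1600 nM, and the step of a 1.1-fold lower number from compound 1 to compound 2 (0.05 log units; within the scatter) lies within the scatter, so the two cannot be told apart. Compound 3 `COc1ccc2[nH]c3c(c2c1)CCNC31CCN(Cc2ccc(F)c(F)c2)CC1` gives 11000 nM; here the step of a 6.1-fold higher number from compound 1 to compound 3 (0.79 log units; beyond the scatter) is a modest but real rise, and a 6.9-fold higher number from compound 2 to compound 3 (0.84 log units; beyond the scatter) tells the same story from the other neighbour.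

Compound 4 `COc1ccc2[nH]c3c(c2c1)CCNC31CCN(Cc2ccc(F)c(F)c2F)CC1` has not yet been measured. Its change from compound 1 is 2,3,4-trifluorophenyl in place of 4-bromo-3-fluorophenyl on a saturated chain carbon bound to an amine nitrogen in a ring. The step that bears on it most directly is a 6.1-fold higher number from compound 1 to compound 3 (0.79 log units; beyond the scatter), where bromo also gave way to fluoro; a 6.9-fold higher number from compound 2 to compound 3 (0.84 log units; beyond the scatter) points the same way. The two extra fluorine atoms of compound 4 have no measured counterpart among these three compounds, so the expectation rests on the loss of bromine alone. The step from compound 1 to compound 4 is therefore expected to be a rise of similar modest size, a 6.1-fold higher number from compound 1 to compound 4 (0.79 log units; beyond the scatter). Compound 4 is estimated at 11000 nM, with a range from 4000 nM to 30000 nM.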

Compound 4, half-maximal effective concentration: 4100 nM
Compound 4: middle estimate off by 2.7-fold (0.43 log units), on the high side; measured number inside the range.
By their numbers in this assay, from the lowest: compounds 2 and 1 (each within the scatter of the next); then compound 4; then compound 3.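

The fluorine count on this benzyl ring matters on its own: an added fluorine on the ring gives a 2.7-fold lower number from compound 3 to compound 4 (0.43 log units; beyond the scatter) in this assay. Among these compounds, the earlier compounds showed only that numbers rose when bromine gave way to fluorine, and this step shows that part of that rise can be won back without bringing bromine back. The recovery is only partial. The 2,3,4-trifluorophenyl group still gives a 2.3-fold higher number from compound 1 to compound 4 (0.36 log units; beyond the scatter) and likewise a 2.6-fold higher number from compound 2 to compound 4 (0.41 log units; beyond the scatter), so on this saturated chain carbon bound to an amine nitrogen in a ring, both bromine-bearing groups remain ahead of the group with three fluorines.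

No evidence is available to explain why either the added fluorine or the bromine shifts the number. Still open, as far as these compounds go, is whether a chlorine atom or a trifluoromethyl group in the place held by bromine would match the bromine compounds, and whether a further fluorine on a bromine-bearing ring would bring the number lower still.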